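A few compounds are considered here, and "the series" means these few. Any claim that something is new, unique, unknown or untested is made for them only; others in the source may bear on it.

Measured compounds in a functional assay on LNCaP cells (Homo sapiens) for antiproliferative activity, read by propidium iodide staining, with a stated time of 96 h; a lower number here means a stronger inhibitor, a higher number a weaker inhibitor:
compound 1, `CC(O)(CSc1ccc(S(F)(F)(F)(F)F)cc1)C(=O)Nc1cccc(S(F)(F)(F)(F)F)c1`, gives 12700 nM
compound 2, `CC(O)(CSc1ccc(F)cc1)C(=O)Nc1cccc(S(F)(F)(F)(F)F)c1`, gives 26900 nM
compound 3, `CC(O)(CS(=O)(=O)c1ccc(S(F)(F)(F)(F)F)cc1)C(=O)Nc1ccc(S(F)(F)(F)(F)F)cc1`, gives 29200 nM

Compound 1 and compound 2 share one core and differ in one place: one fluorine atom in place of a group of 6 heavy atoms (5 fluorine, 1 sulfur; no ring), on an aromatic carbon. That change produced a 2.1-fold higher number from compound 1 to compound 2 (0.33 log units; beyond the scatter). Compound 3 sits on another core; how the core of compound 3 differs from the core of compound 1 is not broken down here. The values of compound 3 and compound 2 lie within the scatter of each other, while compound 3 stands beyond the scatter from compound 1.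

Compound 4, `CC(O)(CS(=O)(=O)c1ccc(F)cc1)C(=O)Nc1ccc(S(F)(F)(F)(F)F)cc1`, is not yet measured. It differs from compound 3 in one place: one fluorine atom in place of a group of 6 heavy atoms (5 fluorine, 1 sulfur; no ring), on an aromatic carbon. The place is described in the same words as for the change from compound 1 to compound 2, so this is the same change on a second core. With one prior instance only, the step is expected to be of similar size: a 2.1-fold higher number from compound 3 to compound 4 (0.31 log units; beyond the scatter), an expectation that rests on compound 1 and compound 2 through a 2.1-fold higher number from compound 1 to compound 2 (0.33 log units; beyond the scatter). For compound 4 in this assay the estimate is 60000 nM, with a plausible range from 30000 nM to 120000 nM.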

Compound 4, half-maximal inhibitory concentration: 18200 nM
Compound 4: the middle estimate sits 3.3-fold (0.52 log units) above what was measured, outside the stated range (below it).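

In this assay, the fluoro for the group of 6 heavy atoms (5 fluorine, 1 sulfur) on the second core gives a 1.6-fold lower number from compound 3 to compound 4 (0.21 log units; within the scatter), so that step is within the scatter and offers no clear effect of its own. Set beside the first instance, the change does not carry over from one core to the other with a constant size in this series: the same change on two cores in this assay, a 2.1-fold higher number (0.33 log units; beyond the scatter) from compound 1 to compound 2 and a 1.6-fold lower number (0.21 log units; within the scatter) from compound 3 to compound 4, 3.4-fold (0.53 log units) apart, beyond the scatter of two such steps. This shows that the step from the core of compound 1 cannot be used as a transfer rule for the core of compound 3, but it does not show which feature of the two cores sets them apart, and one pair per core gives no measure of how either step would hold on a further core.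

From the compounds shown here alone, whether a third core would follow either step remains open. Also open, going by these compounds, is how either core would respond with trifluoromethyl, a nitrile or an amine in that place on the aromatic ring.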